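Swapping the Nitrile-Bearing Phenyl for an Ethyl-Bearing One

The compounds below may be only part of what the source reports. "The series", "measured", "known", "first", "only" and "open" are said of these compounds alone.

Measured so far in a functional assay on HepG2 cells (Homo sapiens) for inhibition, read by MTT assay, with a stated time of 72 h; on this read-out higher numbers stand for weaker inhibition and lower numbers for stronger inhibition:
compound 1 `COc1cccc(-n2cc(COc3cccc(NC(=O)Nc4ccc(Cl)c(C(F)(F)F)c4)c3)nn2)c1` gives 1310 nM
compound 2 `CCc1ccccc1-n1cc(COc2cccc(NC(=O)Nc3ccc(Cl)c(C(F)(F)F)c3)c2)nn1` gives 3530 nM
compound 3 `N#Cc1ccc(-n2cc(COc3cccc(NC(=O)Nc4ccc(Cl)c(C(F)(F)F)c4)c3)nn2)cc1` gives 2980 nM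

Among these three, compound 3 has the second highest number. Compound 2 lies within the scatter of it, while compound 1 stands clearly lower, as the step of a 2.3-fold higher number from compound 1 to compound 3 (0.36 log units; beyond the scatter) shows. Compound 4 `CCc1cccc(-n2cc(COc3cccc(NC(=O)Nc4ccc(Cl)c(C(F)(F)F)c4)c3)nn2)c1` differs from compound 3 in one place: 3-ethylphenyl in place of 4-cyanophenyl on an aromatic nitrogen.

Going by the values given here, two measured steps bear on this. Putting 2-ethylphenyl in place of 3-methoxyphenyl gave a 2.7-fold higher number from compound 1 to compound 2 (0.43 log units; beyond the scatter), and putting 4-cyanophenyl in place of it gave a 2.3-fold higher number from compound 1 to compound 3 (0.36 log units; beyond the scatter). Between the ethyl-bearing and nitrile-bearing compounds themselves the step was a 1.2-fold lower number from compound 2 to compound 3 (0.07 log units; within the scatter). The incoming 3-ethylphenyl carries the ethyl of compound 2, and its name places that ethyl as the methoxy stands in the 3-methoxyphenyl of compound 1. Since compounds 2 and 3 are indistinguishable within the scatter, no step beyond the scatter is expected, though a slight move toward compound 1 is plausible. The expected step in this assay is a 1.3-fold lower number from compound 3 to compound 4 (0.11 log units; within the scatter). Compound 4 is therefore estimated at 2300 nM, within a range of 1000 nM to 5000 nM.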

Compound 4, half-maximal inhibitory concentration: 37900 nM
The estimate for compound 4 lay 16-fold (1.22 log units) below the measured number, outside the stated range (above it).
By their numbers in this assay, from the lowest: compound 1; then compounds 3 and 2 (each within the scatter of the next); then compound 4.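

In this assay, the ring on the aromatic nitrogen proves far less forgiving than the earlier modest steps suggested: 3-ethylphenyl in place of 4-cyanophenyl gives a 13-fold higher number from compound 3 to compound 4 (1.10 log units; beyond the scatter) in this position. Ethyl placement matters, not just its presence, as moving from 2-ethylphenyl to 3-ethylphenyl gives an 11-fold higher number from compound 2 to compound 4 (1.03 log units; beyond the scatter), and the group itself matters too, as ethyl in place of methoxy on the same aromatic carbon gives a 29-fold higher number from compound 1 to compound 4 (1.46 log units; beyond the scatter). No measurement available here explains these large steps. The compounds shown leave open whether this sharp weakening is specific to ethyl or would also appear with 3-methylphenyl or 3-propylphenyl. They also leave open how 4-ethylphenyl would behave, and whether an amine or a carboxylic acid on the ring would track the methoxy of compound 1.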